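The compounds below may be only part of what the source reports. "The series", "measured", "known", "first", "only" and "open" are said of these compounds alone.

Measured compounds:
Compound 1 `N#CC1=C(N)N(c2ccc(S(N)(=O)=O)cc2)C2=C(CCCC2)C1c1cccc([N+](=O)[O-])c1`: 12%
Compound 2 `N#CC1=C(N)N(c2ccc(S(N)(=O)=O)cc2)C2=C(CCCC2)C1c1ccc([N+](=O)[O-])cc1`: 20%

In a functional assay on Ehrlich cells (Mus musculus) for cytotoxicity, read by trypan blue exclusion, with a stated time of 2 h, tested at 100 ug/mL (a higher number here means a stronger effect of the compound at the concentration tested, a lower number a weaker effect), compound 1 gives 12% and compound 2 gives 20%. Compound 2 stands at the upper of these two numbers, yet the step of a number 8 percentage points higher from compound 1 to compound 2 (within the scatter) lies within the usual scatter, so the two compounds cannot be told apart on this read-out.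

Compound 3 `N#CC1=C(N)N(c2ccc(S(N)(=O)=O)cc2)C2=C(CCCC2)C1c1cccs1` is the next compound. It differs from compound 2 in one place: thiophen-2-yl in place of 4-nitrophenyl on a saturated ring carbon. Going by the values given here, the only measured step, a number 8 percentage points higher from compound 1 to compound 2 (within the scatter), also changed the group on that saturated ring carbon, and it stayed within the scatter. Among the compounds with values here, no measured step exchanges the six-membered aromatic ring for a five-membered one with a hetero atom, so there is no direct guide. The step of a number 3 percentage points lower from compound 2 to compound 3 (within the scatter) is therefore expected to remain within the scatter, with no clear direction. For compound 3 the estimate is 17%, with a range from 5% to 32%.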

Compound 3, a percentage reported as activity, at one concentration (the size of the read-out at that concentration, not a potency): 20%
For compound 3 the middle estimate is 3 percentage points below the measured one, and the stated range covers the measured number.
By their numbers in this assay, from the lowest: compounds 1, 2 and 3 (each within the scatter of the next).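

At the saturated ring carbon, the earlier pair only moved the nitro group around a phenyl ring, whereas here the whole ring is exchanged. In this assay, putting thiophen-2-yl in place of the nitrophenyl groups gives no change at the digits printed from compound 2 to compound 3 (within the scatter) and a number 8 percentage points higher from compound 1 to compound 3 (within the scatter). The nitro group and the six-membered aromatic ring are therefore not needed to keep the read-out in this range, and no measured evidence explains this result.

Still open, on these data alone, is whether a different kind of group on that carbon, such as a phenyl ring carrying an amine or a carboxylic acid, or a longer alkyl chain with no ring, would move the number beyond the scatter. Each number also gives the size of the effect at one concentration, so the potency of these compounds remains open.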